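The compounds below may be only part of what the source reports. "The series", "measured", "known", "first", "only" and "open" are said of these compounds alone.

Working notes on the series, read in a functional assay on KB cells (Homo sapiens) for cytotoxicity; on this read-out lower numbers stand for an effect already at smaller amounts and higher numbers for an effect only at larger amounts of compound. Within the data shown here, compound 1 `COC1=C(C)C(=O)/C(=C(O)/C=C/c2ccc(Br)cc2)C(=O)C1(C)C` gives 1.7 ug/mL and compound 2 `COC1=C(C)C(=O)/C(=C(O)/C=C/c2ccc(OC)cc2)C(=O)C1(C)C` gives 3.6 ug/mL, which places compound 2 at the higher of the two numbers so far. Among the measured compounds shown here, the only measured step, a 2.1-fold higher number from compound 1 to compound 2 (0.33 log units; beyond the scatter), is modest and comes from methoxy in place of bromo on an aromatic carbon.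

The next compound is compound 3 `COC1=C(C)C(=O)/C(=C(O)/C=C/c2cccc(OC)c2)C(=O)C1(C)C`, which has the same atoms as compound 2, joined differently: 3-methoxyphenyl in place of 4-methoxyphenyl on a double-bonded chain carbon bound to a double-bonded chain carbon. For the measured compounds named here, no measured pair tests this kind of change directly, so the step between compound 1 and compound 2 bears on it only loosely. That step, a 2.1-fold higher number from compound 1 to compound 2 (0.33 log units; beyond the scatter), exchanged one group for a different one and still stayed modest, whereas here the methoxy group is retained. The expectation in this assay is therefore no step beyond the scatter, with no direction favoured beyond a slight lean to a lower number, and the estimated step is a 1.2-fold lower number from compound 2 to compound 3 (0.08 log units; within the scatter). For compound 3 the expected value is 3 ug/mL, with an estimated range of 1.4 ug/mL to 6.5 ug/mL.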

Compound 3, concentration for half-maximal effect: 3.3 ug/mL
Compound 3: middle estimate off by 1.1-fold (0.04 log units), on the low side; low and high end bracket the measured number.
By their numbers in this assay, from the lowest: compounds 1, 3 and 2 (each within the scatter of the next, the first and the last beyond it).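

In this assay, 3-methoxyphenyl in place of 4-methoxyphenyl on a double-bonded chain carbon bound to a double-bonded chain carbon gives a 1.1-fold lower number from compound 2 to compound 3 (0.04 log units; within the scatter), the first sign that, for these two attachments of the methoxyphenyl group, the change leaves the read-out within the scatter. The exchange of 4-bromophenyl for 3-methoxyphenyl gives a 1.9-fold higher number from compound 1 to compound 3 (0.29 log units; within the scatter), whereas the exchange for 4-methoxyphenyl gave a 2.1-fold higher number from compound 1 to compound 2 (0.33 log units; beyond the scatter), so compound 1 is separated from compound 2 but not from compound 3, and replacing the bromophenyl with a methoxyphenyl does not carry a step beyond the scatter in both cases. No independent measurement is at hand that bears on these small steps.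

On these data alone, whether the read-out remains this insensitive with an amine, a hydroxyl or a carboxylic acid on the aromatic ring in place of methoxy or bromo remains open. Also open, as far as these compounds go, is whether a longer chain in place of the present double-bonded chain, or a change in the shared core, would produce a step well beyond the scatter, since all three compounds keep both unchanged.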